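Side-chain swap at the shared core: expected lipophilicity

The source may hold more compounds than are shown below. What is called first, only, known or untested is meant among the compounds shown, and "the series" means these compounds.

Three compounds of the shared core have numbers in a physicochemical assay for lipophilicity, read by HPLC, measured as octanol-water partition; a lower number here means a more polar compound, a higher number a more lipophilic compound. Compound 1 `CN1CCN(C[C@H]2CN(c3ccc(-n4cc(-c5ccccn5)cn4)c(F)c3)C(=O)O2)CC1` gives 2.2. Compound 2 `O=C1O[C@@H](CN2CCC(O)CC2)CN1c1ccc(-n2cc(-c3ccccn3)cn2)c(F)c1` gives 1.63, the step being a number 0.57 log units lower from compound 1 to compound 2 (beyond the scatter). Compound 3 `O=C1O[C@@H](Cn2ccnc2)CN1c1ccc(-n2cc(-c3ccccn3)cn2)c(F)c1` gives 1.73; the step there is a number 0.47 log units lower from compound 1 to compound 3 (beyond the scatter), while the comparison with compound 2 is a number 0.10 log units higher from compound 2 to compound 3 (within the scatter). Compound 3 thus stands second highest of the three, within the scatter of compound 2 and separated beyond the scatter only from compound 1.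

Compound 4 `O=C1O[C@@H](CNC(=O)C(F)(F)F)CN1c1ccc(-n2cc(-c3ccccn3)cn2)c(F)c1` differs from compound 3 at the one position where the measured compounds also vary: ((trifluoromethyl)carbonyl)amino in place of 1H-imidazol-1-yl on a saturated chain carbon bound to a saturated ring carbon. The two steps at this position that reached beyond the scatter, a number 0.57 log units lower from compound 1 to compound 2 (beyond the scatter) and a number 0.47 log units lower from compound 1 to compound 3 (beyond the scatter), were both modest, and the third, a number 0.10 log units higher from compound 2 to compound 3 (within the scatter), stayed within the scatter. Going by the values given here, none of the measured compounds carries the entering group, so no measured step weighs it directly. The expected step is small, a number 0.17 log units higher from compound 3 to compound 4 (within the scatter), leaning slightly upward. Compound 4 is estimated at 1.9, in the range 1.4 to 2.5.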

Compound 4, partition coefficient: >= 1.78
Compound 4: a limit, no number; the forecaster's own chance of this, stated with the estimate: 2%; the middle value lies beyond the limit too.
By their numbers in this assay, from the lowest: compounds 2 and 3 (each within the scatter of the next); then compound 1.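

In this assay compound 4 carries a limit and not a number: the limit of >= 1.78 in this assay, at which 1 of the 4 values shown sits. ((Trifluoromethyl)carbonyl)amino is the only group shown at this place, on a saturated chain carbon bound to a saturated ring carbon, that has no ring, and it gives a number at least 0.05 log units higher from compound 3 to compound 4 (that floor lies within the scatter) and a number at least 0.15 log units higher from compound 2 to compound 4 (that floor lies within the scatter); these floors show no fall from either ring-bearing group but leave each step without an upper bound. The step from compound 1 cannot be read, so the position of compound 4 relative to compound 1 remains undetermined.

The compounds shown leave open how an acetylamino group or a plain primary amine would read at this place. Without such a comparison, the contribution of the trifluoromethyl cannot be separated from that of the amide linkage.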